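A few compounds are considered here, and "the series" means these few. Any claim that something is new, unique, unknown or untested is made for them only; others in the source may bear on it.

Working notes on the series. Compound 1 `C[C@@H](NC(=O)Nc1ccccc1C(C)(C)C)c1ccccc1` gives 17% in an ADME assay on the whole organism with Oryza sativa as the target, tested at 10 uM; on this read-out lower numbers stand for a stronger effect and higher numbers for a weaker effect at the one concentration tested. Compound 2 `C[C@@H](NC(=O)Nc1ccccc1C(F)(F)F)c1ccccc1` gives 54% in this assay, and compound 3 `C[C@H](NC(=O)Nc1ccccc1C(F)(F)F)c1ccccc1` gives 97% in this assay. Compound 2 thus stands second highest of the three numbers, closer to compound 1 than to compound 3.

Two measured steps are known. From compound 1 to compound 2, with trifluoromethyl in place of tert-butyl on an aromatic carbon, this assay moved a number 37 percentage points higher from compound 1 to compound 2 (beyond the scatter). From compound 2 to compound 3 it moved a number 43 percentage points higher from compound 2 to compound 3 (beyond the scatter), a step that rests on (the fact that compounds 2 and 3 differ only in the configuration as drawn).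

Compound 4 `C[C@@H](NC(=O)Nc1ccccc1Br)c1ccccc1` is not yet measured. Relative to compound 2 the change is bromo in place of trifluoromethyl on an aromatic carbon. Within the data shown here, only the step from compound 1 to compound 2 bears on it, being a substituent exchange on the same aromatic carbon; that step was large. The configurational step from compound 2 to compound 3 does not bear on it. A large step in this assay is therefore expected, but its direction cannot be read from one step, so the estimate stays wide. Compound 4 is expected at 60%, range 30% to 90%, an expected step of a number 6 percentage points higher from compound 2 to compound 4 (within the scatter).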

Compound 4, a percentage reported as activity, at one concentration (the size of the read-out at that concentration, not a potency): 94%
The estimate for compound 4 lay 34 percentage points below the measured number; the measured number lies above the stated range.
By their numbers in this assay, from the lowest: compound 1; then compound 2; then compounds 4 and 3 (each within the scatter of the next).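

On this aromatic carbon, the exchange of one group for another is enough to carry this assay across much of the span seen in the series: a number 40 percentage points higher from compound 2 to compound 4 (beyond the scatter) and a number 77 percentage points higher from compound 1 to compound 4 (beyond the scatter) are both large steps, with the configuration as drawn held the same. The three groups thus separate clearly, with tert-butyl giving the lowest number, trifluoromethyl the middle one and bromo the highest, so a substituent exchange here can be as large as the configurational change. Nothing in hand on these compounds explains why bromo differs from trifluoromethyl or tert-butyl at this position.

On these data alone, whether the opposite drawn configuration would shift the number with bromo or tert-butyl as it does with trifluoromethyl remains open. Also open, as far as these compounds go, is where a chloro, methoxy, nitrile or amine group on the same aromatic carbon would fall.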